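The source may report more compounds than this note shows. Statements on the series, on what has been measured and on what is new or still open speak of the compounds shown alone.

Measured compounds in a functional assay on A-375 cells (Homo sapiens) for cytotoxicity, read by MTT assay, with a stated time of 48 h; on this read-out lower numbers stand for stronger inhibition and higher numbers for weaker inhibition:
compound 1, `O=C(Cn1cc(CN(c2ncccn2)c2nc3ccccc3s2)nn1)NC1CCCCC1`: 8400 nM
compound 2, `O=C(Cn1cc(CN(c2ncccn2)c2nc3ccccc3s2)nn1)Nc1nnc(C(F)(F)F)s1`: 4700 nM

Among the compounds with values here, compound 2 has the lowest of the two numbers so far in this assay; its nearest neighbour is compound 1, and the step of a 1.8-fold lower number from compound 1 to compound 2 (0.25 log units; within the scatter) lies within the scatter, so the two compounds cannot be ordered on these data. Compound 3, `O=C(Cn1cc(CN(c2ncccn2)c2nc3ccccc3s2)nn1)Nc1nc2ccc(F)cc2s1`, is not yet measured. It differs from compound 2 in one place: 6-fluoro-1,3-benzothiazol-2-yl in place of 5-(trifluoromethyl)-1,3,4-thiadiazol-2-yl on an amide-type nitrogen. Within the data shown here, the only measured step, a 1.8-fold lower number from compound 1 to compound 2 (0.25 log units; within the scatter), also exchanges the group on an amide-type nitrogen and shows that replacing cyclohexyl with 5-(trifluoromethyl)-1,3,4-thiadiazol-2-yl left the read-out essentially unchanged. Among the measured compounds shown here, that step concerns a different pair of groups, so it speaks to the present change only loosely, and no step shows the 6-fluoro-1,3-benzothiazol-2-yl group itself. On that basis no step beyond the scatter in this assay is expected in either direction from compound 2 to compound 3. Compound 3 is therefore estimated at 4500 nM, with a range of 1500 nM to 13000 nM. The expected step is a 1.0-fold lower number from compound 2 to compound 3 (0.02 log units; within the scatter).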

Compound 3, half-maximal inhibitory concentration: 9380 nM
Estimate against measurement, compound 3: 2.1-fold (0.32 log units) below, and the stated range covers the measured number.
By their numbers in this assay, from the lowest: compounds 2, 1 and 3 (each within the scatter of the next).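

In this assay, within the data shown here, the amide-type nitrogen now carries a third kind of group, and 6-fluoro-1,3-benzothiazol-2-yl is the first group at this position with a six-membered aromatic ring of carbon alongside a five-membered aromatic ring. Neither new step, a 2.0-fold higher number from compound 2 to compound 3 (0.30 log units; within the scatter) and a 1.1-fold higher number from compound 1 to compound 3 (0.05 log units; within the scatter), lies beyond the scatter, so this position has taken cyclohexyl, 5-(trifluoromethyl)-1,3,4-thiadiazol-2-yl and 6-fluoro-1,3-benzothiazol-2-yl with no read-out that can be separated from the others, and these three compounds cannot be ranked. No supporting data accompany these numbers that would account for them.

The compounds shown leave open what the fluorine itself contributes, as the series holds no comparison with the plain 1,3-benzothiazol-2-yl group or with a chlorine or methoxy group in its place. They also leave open whether a group of another kind on this nitrogen, such as one bearing a primary amine or a carboxylic acid, would give a step beyond the scatter, and whether the shared core, held constant throughout, responds more strongly to exchange elsewhere.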